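The compounds below may be only part of what the source reports. "The series", "measured", "known", "first", "only" and "open" are said of these compounds alone.

Measured compounds:
Compound 1, `COC/C1=C/C[C@](C)(CCC=C(C)C)/C=C/[C@@H](OC(=O)C=C(C)C)[C@](C)(O)/C=C/C1=O` — 3850 nM
Compound 2, `C=C1/C=C/C(=O)/C(CO)=C\C[C@](C)(CCC=C(C)C)/C=C/[C@H]1OC(=O)C=C(C)C` — 2970 nM

In a functional assay on SW480 cells (Homo sapiens) for antiproliferative activity, read by MTT assay, with a stated time of 48 h (on this read-out lower numbers stand for stronger inhibition and higher numbers for weaker inhibition), compound 1 gives 3850 nM, and it stands at the top of the two numbers recorded there. Its nearest neighbour, compound 2, gives 2970 nM in this assay, a gap that falls within the usual scatter of repeated measurements, so the two cannot be told apart on these data. Within the data shown here, no pair of measured compounds differing in a single place exists, so no step has been quantified.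

Compound 3, `CC(C)=CCC[C@]1(C)/C=C/[C@@H](OC(=O)C=C(C)C)[C@](C)(O)/C=C/C(=O)/C(C[Si](C)(C)C(C)(C)C)=C\C1`, has not yet been measured. It derives from compound 1 by a group of 7 heavy atoms (6 carbon, 1 silicon; no ring) in place of a group of 2 heavy atoms (1 carbon, 1 oxygen; no ring), on a saturated chain carbon bound to a double-bonded ring carbon. Among the measured compounds shown here, nothing among the measured compounds shows how this assay responds to such a swap, and the two known values sit close together, which gives no slope to extrapolate along. The step of a 1.3-fold lower number from compound 1 to compound 3 (0.11 log units; within the scatter) is therefore expected to be small, with no firm direction beyond the scatter. Compound 3 is expected to give 3000 nM in this assay, within a range of 1000 nM to 9000 nM.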

Compound 3, half-maximal inhibitory concentration: 3350 nM
Compound 3: the middle estimate sits 1.1-fold (0.05 log units) below what was measured; the measured number falls inside the stated range.
By their numbers in this assay, from the lowest: compounds 2, 3 and 1 (each within the scatter of the next).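

In this assay, among these compounds, putting the group of 7 heavy atoms (6 carbon, 1 silicon; no ring) in place of methoxy, on a saturated chain carbon bound to a double-bonded ring carbon, gives a 1.1-fold lower number from compound 1 to compound 3 (0.06 log units; within the scatter) and so supplies the first quantified single-place step on this core. For this pair, the read-out therefore does not separate a group of 2 heavy atoms with 1 hydrogen-bond acceptor from a much larger silicon-bearing group with 0 hydrogen-bond acceptors, so neither the added size nor the missing acceptor moves the number beyond the scatter at this place. No measurement in hand accounts for why the number holds across this swap.

One step at one place cannot show whether this insensitivity extends to groups of other kinds, such as an amine, a carboxylic acid or a longer alkyl chain on the same carbon. The compounds shown also leave open whether any single change to the shared core can shift the number beyond the scatter, since no such step has yet appeared in this series.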